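The source may report more compounds than this note shows. Statements on the series, on what has been measured and on what is new or still open speak of the compounds shown alone.

Measured so far in an ADME assay (liver) for metabolic stability, with Liver microsome (Homo sapiens) as the target, using microsomes and NADPH, with a stated time of 30 min, tested at 1 uM; a higher number here means faster removal of the compound, a lower number slower removal:
- compound 1 `CC(C)(O)C#Cc1cc(C(O)(C(F)(F)F)C(F)(F)F)cnc1N1CCN(S(=O)(=O)c2ccc(N)nc2)CC1`: < 14 mL.min-1.g-1 (a limit)
- compound 2 `CCn1cc(-c2cc(C(O)(C(F)(F)F)C(F)(F)F)cnc2N2CCN(S(=O)(=O)c3ccc(N)nc3)CC2)cn1`: 20 mL.min-1.g-1
- compound 3 `Nc1ccc(S(=O)(=O)N2CCN(c3ncc(C(O)(C(F)(F)F)C(F)(F)F)cc3-c3ccoc3)CC2)cn1`: < 14 mL.min-1.g-1 (a limit)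

Compound 3 has no exact number, only the limit < 14 mL.min-1.g-1. This is the limit of < 14 mL.min-1.g-1 in this assay, at which 2 of the 3 values shown sit, so compound 3 cannot be ranked against compound 1.

Next is compound 4 `Nc1ccc(S(=O)(=O)N2CCN(c3ncc(C(O)(C(F)(F)F)C(F)(F)F)cc3-c3ccccc3O)CC2)cn1`: 2-hydroxyphenyl in place of furan-3-yl on an aromatic carbon. In words, 2-hydroxyphenyl replaces furan-3-yl on an aromatic carbon, ortho to a large group.

Three measured steps swap a group at this same place. Two are an at least 1.4-fold higher number from compound 1 to compound 2 (0.15 log units; that floor lies within the scatter) and an at least 1.4-fold lower number from compound 2 to compound 3 (0.15 log units; that floor lies within the scatter), and both have floors within the scatter. The third, a step that the two limits leave unreadable from compound 1 to compound 3, is unreadable between two limits. None of the three shows a readable change beyond the scatter, but none involves a 2-hydroxyphenyl group, so the read-across is weak.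

In this assay, the expected step is a number no lower from compound 3 to compound 4 (the limit leaves the size open), with no shift beyond the scatter expected in either direction. A further limit result is about as likely as a number.

For compound 4, the estimated value is 14 mL.min-1.g-1, with an expected range of 8 mL.min-1.g-1 to 28 mL.min-1.g-1.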

Compound 4, intrinsic clearance in microsomes: 22 mL.min-1.g-1
Estimate against measurement, compound 4: 1.6-fold (0.20 log units) below, within the range that was stated.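

In this assay, within the data shown here, the comparison between compound 2 and compound 4 is the first at this place that joins two numbers rather than a limit: there is a 1.1-fold higher number from compound 2 to compound 4 (0.04 log units; within the scatter), so 1-ethyl-1H-pyrazol-4-yl and 2-hydroxyphenyl cannot be told apart here. The steps from the other two compounds are an at least 1.5-fold higher number from compound 3 to compound 4 (0.19 log units; that floor lies within the scatter) and an at least 1.5-fold higher number from compound 1 to compound 4 (0.19 log units; that floor lies within the scatter), so neither shows a change beyond the scatter. The results for compound 1 and compound 3 are limits, not numbers: the limit of < 14 mL.min-1.g-1 in this assay, at which 2 of the 4 values shown sit.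

On these data alone, how far compound 1 and compound 3 truly lie from compound 4 remains open. Also open, as far as these compounds go, is how phenyl without the hydroxy group, or a group carrying an amine or a carboxylic acid, would read at this place.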